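Benzyloxy for Bromo: Expectation for Compound 4

The source may report more compounds than this note shows. Statements on the series, on what has been measured and on what is new or still open speak of the compounds shown alone.

Compound 1 `Cc1cc(O)c(C(=O)/C=C/c2ccccc2)c(-c2ccc(Br)cc2)c1C(=O)/C=C/c1ccccc1` gives 8000 nM in a functional assay on MDA-MB-231 cells (Homo sapiens) for cytotoxicity, read by MTT assay, with a stated time of 24 h (on this read-out higher numbers stand for weaker inhibition and lower numbers for stronger inhibition), the lowest of the three measured numbers. Compound 2 `Cc1cc(O)c(C(=O)/C=C/c2ccc(OCc3ccccc3)cc2)c(-c2ccc(Br)cc2)c1C(=O)/C=C/c1ccc(OCc2ccccc2)cc1` gives 20000 nM in this assay, and compound 3 `Cc1cc(O)c(C(=O)/C=C/c2ccc(OCc3ccccc3)cc2)c(-c2ccc(OCc3ccccc3)cc2)c1C(=O)/C=C/c1ccc(OCc2ccccc2)cc1` gives 20000 nM. The difference between the cores of compound 1 and compound 2 is not broken down here. Between the two measured analogues the change benzyloxy in place of bromo on an aromatic carbon produced the step of no change at the digits printed from compound 2 to compound 3 (within the scatter). Compound 4 `Cc1cc(O)c(C(=O)/C=C/c2ccccc2)c(-c2ccc(OCc3ccccc3)cc2)c1C(=O)/C=C/c1ccccc1` differs from compound 1 by the same change, (benzyloxy in place of bromo on an aromatic carbon). Because the earlier step of no change at the digits printed from compound 2 to compound 3 (within the scatter) stayed within the scatter, the step of no change at the digits printed from compound 1 to compound 4 (within the scatter) is expected to be of the same small size. Compound 4 is therefore estimated at 8000 nM in this assay, with a likely range from 4000 nM to 16000 nM.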

Compound 4, half-maximal inhibitory concentration: "not active" (no number reported)
The entry for compound 4 holds no number; there is nothing to compare the estimate with.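

Among these compounds, compound 4 is reported as "not active" without a number, so no step from compound 1 to compound 4 can be read in this assay here. No evidence bears on this result. The compounds shown leave open how far compound 4 lies from compound 1.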